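Pyridinylmethyl for cyanomethyl on a uracil-type cytotoxicity series

The compounds below may be only part of what the source reports. "The series", "measured", "known", "first", "only" and "open" are said of these compounds alone.

The measured compounds:
Compound 1, `Cc1cc(C)cc(Cn2c(=O)cc(N)n(CC#N)c2=O)c1`: > 100000 nM
Compound 2, `Cc1cc(C)cc(Cn2c(=O)cc(N=[N+]=[N-])n(CC#N)c2=O)c1`: 60000 nM
Compound 3, `CC(=O)Nc1cc(=O)n(Cc2cc(C)cc(C)c2)c(=O)n1Cc1ccccc1`: > 100000 nM

Among the measured compounds shown here, in an ADME assay on MT4 cells (Homo sapiens) for cytotoxicity, read by MTT assay, with a stated time of 4 days (on this read-out higher numbers stand for lower toxicity in this test and lower numbers for higher toxicity in this test), compound 2 gives 60000 nM, the only numerical value in the set. For compound 1 the result is a limit of the assay, > 100000 nM. For compound 3 the result is likewise a limit, > 100000 nM. For the measured compounds named here, compound 2 therefore stands alone as the one compound with a measured half-maximal cytotoxic concentration, and the other two sit at the limit of > 100000 nM in this assay, at which 2 of the 3 values shown sit.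

Compound 4, `Cc1cc(C)cc(Cn2c(=O)cc(N=[N+]=[N-])n(Cc3ccncc3)c2=O)c1`, has not yet been measured in this assay. It differs from compound 2 by pyridin-4-yl in place of cyano on a saturated chain carbon bound to an aromatic nitrogen. None of the measured steps touches this position: the one step shown, an at least 1.6-fold lower number from compound 1 to compound 2 (0.22 log units; that floor lies within the scatter), concerns the azido group and is within the scatter. The data therefore give no direction for the change; compound 3, which carries a benzyl group on that nitrogen, sits at the limit.

On this basis the writer expects compound 4 to show a 1.5-fold higher number from compound 2 to compound 4 (0.18 log units; within the scatter), giving an estimate of 90000 nM with a range from 35000 nM to 250000 nM.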

Compound 4, half-maximal cytotoxic concentration: 59000 nM
For compound 4 the middle estimate is 1.5-fold (0.18 log units) above the measured one, within the range that was stated.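

In this assay, among the compounds shown here, the one step at this position reads a 1.0-fold lower number from compound 2 to compound 4 (0.01 log units; within the scatter). For the compounds shown here, the earlier compounds could not show this, as their only step concerned the azido group: with azido held constant, exchanging cyanomethyl for (pyridin-4-yl)methyl, which brings in a six-membered aromatic ring, does not separate the two compounds on this read-out. Compound 1 and compound 3 remain limits of the assay, not numbers: the limit of > 100000 nM in this assay, at which 2 of the 4 values shown sit.

As far as these compounds go, whether a pyridin-2-yl or a phenyl group on the same chain carbon, or a longer chain carrying the pyridin-4-yl, would behave alike stays open. So does the effect of an amino group in place of azido alongside (pyridin-4-yl)methyl, and compound 3 cannot settle either question, as it differs from compound 4 in more than one place.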